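Swapping One Aromatic Group at the Assay Limit

The source may report more compounds than this note shows. Statements on the series, on what has been measured and on what is new or still open speak of the compounds shown alone.

In a functional assay on L5178Y cells (Mus musculus) for inhibition, read by MTT assay, with a stated time of 24 h (a higher number here means a weaker inhibitor, a lower number a stronger inhibitor), compound 2 `COc1cccc(/C=N/N=C2\C[C@@H](c3ccc(O)cc3)Oc3cc(OC)cc(O)c32)c1` gives >= 11300 nM as a limit and not a number. Compound 1 `Oc1ccc([C@@H]2C/C(=N\Nc3cnccn3)c3c(O)cc(O)cc3O2)cc1` gives >= 11300 nM as a limit as well. Compound 3 `CN(C)C(=S)N/N=C1\C[C@@H](c2ccc(O)cc2)Oc2cc(O)cc(O)c21` gives >= 11300 nM as a limit as well. Compound 4 `COc1cc(O)c2c(c1)O[C@H](c1ccc(O)cc1)C/C2=N\Nc1ccc(Br)cn1` differs from compound 2 by a group of 8 heavy atoms (5 carbon, 2 nitrogen, 1 bromine; one six-membered aromatic ring with 1 hetero atom) in place of a group of 10 heavy atoms (8 carbon, 1 nitrogen, 1 oxygen; one six-membered aromatic ring of carbon only), on a double-bonded nitrogen and so carries a (5-bromopyridin-2-yl)amino group. Within the data shown here, the one measured step, a step that the two limits leave unreadable from compound 1 to compound 3, offers no size to carry over. All that the numbers show is the limit of >= 11300 nM in this assay, at which 3 of the 3 values shown sit, and this sets no direction. The estimated step that the limit leaves unreadable from compound 2 to compound 4 is therefore expected to show no clear size or direction. Compound 4 is expected near 15000 nM with an estimated range from 6000 nM to 40000 nM in this assay once measured.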

Compound 4, half-maximal inhibitory concentration: 4300 nM
Estimate against measurement, compound 4: 3.5-fold (0.54 log units) above; measured number below the stated range.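

Putting the (5-bromopyridin-2-yl)amino group on the double-bonded nitrogen, in place of the group with a carbon-only aromatic ring, gives an at least 2.6-fold lower number from compound 2 to compound 4 (0.41 log units; beyond the scatter) in this assay. Among these compounds, this is the first step here with a readable direction, and it shows that a change at this place can move the result. Compound 4 alone gives a number, and the other compounds remain at a limit: the limit of >= 11300 nM in this assay, at which 3 of the 4 values shown sit.

The compounds shown do not separate the part played by the bromine from that of the rest of the new group. Going by these compounds, what a chlorine or a methyl in place of the bromine would give remains open.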